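Allyl to benzyl on the tertiary carbinol

A few compounds are considered here, and "the series" means these few. Any claim that something is new, unique, unknown or untested is made for them only; others in the source may bear on it.

Among the measured compounds shown here, compound 1 (`C=CCC(O)(c1ccc(OC)c(OC)c1OC)c1cccc2ccccc12`) gives 10700 nM in a functional assay on A549 cells (Homo sapiens) for inhibition, read by sulforhodamine B assay, with a stated time of 48 h (a higher number here means a weaker inhibitor, a lower number a stronger inhibitor), and holds the only actual number so far. Compound 2 (`COc1ccc(C(c2ccc(OCCO)cc2)c2cccc3ccccc23)c(OC)c1OC`) gives only a limit (> 20000 nM). Compound 3 (`COc1ccc(C(O)(Cc2ccccc2)c2cccc3ccccc23)c(OC)c1OC`) is not yet measured. It differs from compound 1 by the change from allyl to benzyl (phenyl in place of vinyl on a saturated chain carbon, two bonds along the chain from two aromatic carbons and an oxygen on a saturated carbon), which is phenyl in place of vinyl on a saturated chain carbon, two bonds along the chain from two aromatic carbons and an oxygen on a saturated carbon. For the measured compounds named here, no measured step bears on this change, so the expectation rests on the value of compound 1 (10700 nM) alone. No shift beyond the usual scatter is expected in this assay, and the estimated step (a 1.1-fold higher number from compound 1 to compound 3 (0.05 log units; within the scatter)) is small and slightly towards weaker inhibition. The expected value for compound 3 is 12000 nM (estimated range 5000 nM to 20000 nM).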

Compound 3, half-maximal inhibitory concentration: > 20000 nM
Compound 3 was reported as a limit; the forecaster's own chance of this, stated with the estimate: 30%; at least 1.6-fold (0.22 log units) between middle value and limit.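

In this assay compound 3 is reported only as a limit, > 20000 nM, and not as a number. The step is an at least 1.8-fold higher number from compound 1 to compound 3 (0.27 log units; that floor lies within the scatter), so swapping allyl for benzyl at this position gives no sign of stronger inhibition, yet the floor of the step does not separate the pair beyond the usual scatter. The true size of the change cannot be read, because the reading for compound 3 stops at the limit: the limit of > 20000 nM in this assay, at which 2 of the 3 values shown sit.

Still open, going by these compounds, is how other groups in place of vinyl or phenyl at this position would compare with compound 1 at 10700 nM, such as a longer saturated chain or a chain ending in an amine or a carboxylic acid. Among the compounds shown here, with only one pair differing in one place, nothing yet shows whether the step from allyl to benzyl would repeat elsewhere.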